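The source may report more compounds than this note shows. Statements on the series, on what has been measured and on what is new or still open speak of the compounds shown alone.

Compound 3, `N#Cc1cccc(C(=O)NCN2CCC(c3cccc[n+]3[O-])CC2)c1`, gives 840 nM in a functional assay on HEK293 cells for agonist activity at D(4) dopamine receptor (Homo sapiens), read by FLIPR (a higher number here means that more compound is needed for the effect, a lower number that less compound is needed), the highest of the three numbers in hand. Compound 1, `O=C(NCN1CCC(c2cccc[n+]2[O-])CC1)c1ccccc1`, with hydrogen at that position, gives 532 nM, and the step of a 1.6-fold higher number from compound 1 to compound 3 (0.20 log units; within the scatter) lies within the scatter. Compound 2, `Cc1cccc(C(=O)NCN2CCC(c3cccc[n+]3[O-])CC2)c1`, gives 89 nM and stands furthest away, the step of a 9.4-fold higher number from compound 2 to compound 3 (0.97 log units; beyond the scatter) being beyond the scatter. The step of a 6.0-fold lower number from compound 1 to compound 2 (0.78 log units; beyond the scatter) shows that a methyl at this aromatic carbon lowers the number compared with hydrogen.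

Compound 4, `CCOc1cccc(C(=O)NCN2CCC(c3cccc[n+]3[O-])CC2)c1`, differs from compound 3 by ethoxy in place of cyano on an aromatic carbon. The measured steps that bear on it are a 9.4-fold higher number from compound 2 to compound 3 (0.97 log units; beyond the scatter) and a 1.6-fold higher number from compound 1 to compound 3 (0.20 log units; within the scatter): removing the cyano brought the number back to the region of compounds 1 and 2. Going by the values given here, no measured step involves ethoxy, so how far the number moves beyond that region is uncertain. For compound 4 a lower number than that of compound 3 is expected, corresponding to a 3.8-fold lower number from compound 3 to compound 4 (0.58 log units; beyond the scatter), placing it near 220 nM in this assay, within 60 nM to 800 nM.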

Compound 4, half-maximal effective concentration: 324 nM
Beside the measured number, compound 4's estimate is 1.5-fold (0.17 log units) below it; low and high end bracket the measured number.
By their numbers in this assay, from the lowest: compound 2; then compounds 4, 1 and 3 (each within the scatter of the next, the first and the last beyond it).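

Ethoxy at this aromatic carbon gives a number that cannot be told apart from that of the unsubstituted compound in this assay, since the step of a 1.6-fold lower number from compound 1 to compound 4 (0.22 log units; within the scatter) lies within the scatter. It nevertheless separates from cyano, with the step of a 2.6-fold lower number from compound 3 to compound 4 (0.41 log units; beyond the scatter), although hydrogen and cyano lay within the scatter of each other, while the step of a 3.6-fold higher number from compound 2 to compound 4 (0.56 log units; beyond the scatter) shows that the low number seen with methyl does not carry over to ethoxy. Nothing measured here bears on why these groups differ.

Going by these compounds, whether methoxy or ethyl would stand with methyl or with ethoxy remains open, as does the effect of an amine or a carboxylic acid at this carbon. All the groups shown also sit at this one aromatic carbon, so what they would do elsewhere on the ring is unknown.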